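Removing a hydroxymethyl from a selenium-bearing quinoline analogue

A few compounds are considered here, and "the series" means these few. Any claim that something is new, unique, unknown or untested is made for them only; others in the source may bear on it.

Compound 1 `OCC#CCSc1cnc2ccccc2c1[Se]CC#CCBr` gives 0.2 ug/mL in a functional assay on CCRF-CEM cells (Homo sapiens) for cytotoxicity, read by sulforhodamine B assay, with a stated time of 72 h; on this read-out lower numbers stand for stronger inhibition and higher numbers for weaker inhibition. Its two measured companions are compound 2 `OCC#CCSc1cnc2ccccc2c1SCC#CCO` and compound 3 `C#CCSc1c(SCC#CCO)cnc2ccccc12`. In this assay compound 2 gives 2.6 ug/mL, and compound 3 gives 2.7 ug/mL. The core of compound 1 differs from that of compound 2 by a group of 6 heavy atoms (4 carbon, 1 selenium, 1 bromine; no ring) in place of a group of 6 heavy atoms (4 carbon, 1 oxygen, 1 sulfur; no ring), on an aromatic carbon; this difference goes with a 13-fold higher number from compound 1 to compound 2 (1.11 log units; beyond the scatter), and a 14-fold higher number from compound 1 to compound 3 (1.13 log units; beyond the scatter) is of similar size.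

Between compound 2 and compound 3 the change is hydrogen in place of hydroxymethyl on a triple-bonded carbon, and it produced a 1.0-fold higher number from compound 2 to compound 3 (0.02 log units; within the scatter). The unmeasured compound 4 `C#CCSc1cnc2ccccc2c1[Se]CC#CCBr` arises from compound 1 by the same change, (hydrogen in place of hydroxymethyl on a triple-bonded carbon), at a place described in the same words. The step to compound 4 is expected to be small, a 1.1-fold higher number from compound 1 to compound 4 (0.04 log units; within the scatter), because a 1.0-fold higher number from compound 2 to compound 3 (0.02 log units; within the scatter) lay within the scatter, with the caveat that compound 1 carries the other core and that the change has been seen only once. Compound 4 is therefore estimated at 0.22 ug/mL in this assay, between 0.1 ug/mL and 0.5 ug/mL.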

Compound 4, concentration for 50% inhibition: 0.3 ug/mL
Compound 4: middle estimate off by 1.4-fold (0.13 log units), on the low side; the measured number falls inside the stated range.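

On the core that carries selenium and bromine, hydrogen in place of hydroxymethyl on a triple-bonded carbon gives a 1.5-fold higher number from compound 1 to compound 4 (0.18 log units; within the scatter) in this assay, and this step matches the one seen on the other core: the same change on two cores in this assay, a 1.0-fold higher number (0.02 log units; within the scatter) from compound 2 to compound 3 and a 1.5-fold higher number (0.18 log units; within the scatter) from compound 1 to compound 4, 1.4-fold (0.16 log units) apart, within the scatter of two such steps Across these two pairs, then, the change carried from one core to the other without a step beyond the scatter on either core, and the two cores kept their separate levels of activity. Among the compounds shown here, this rests on only two pairs in a single cell assay, so it does not show that the change would stay this small on other cores, and it says nothing of why it is small.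

The compounds shown leave open whether an amine, a carboxylic acid or a longer chain on the triple-bonded carbon would behave as hydrogen and hydroxymethyl do here. They also leave open whether selenium or bromine goes with a 13-fold higher number from compound 1 to compound 2 (1.11 log units; beyond the scatter); the two change together in that step.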